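Swapping Fluoro for Methyl on a Cyclopropyl Amide

The source may report more compounds than this note shows. Statements on the series, on what has been measured and on what is new or still open speak of the compounds shown alone.

Compound 1 `CC(C)C(=O)N1CC2CC(C1)N2` — 71%
Compound 2 `O=C(C1CCC1)N1CC2CC(C1)N2` — 99%
Compound 3 `O=C([C@@H]1C[C@H]1F)N1CC2CC(C1)N2` — 110%
Compound 4 `C[C@@H]1C[C@H]1C(=O)N1CC2CC(C1)N2` — not yet measured

All three measured compounds share one core and differ only in the group on the carbonyl carbon, and all were tested in an assay on SH-EP1 cells for agonist activity at Neuronal acetylcholine receptor; alpha4/beta2 (Homo sapiens), read by FLIPR and calcium flux; on this read-out higher numbers stand for larger maximal responses and lower numbers for smaller maximal responses. Compound 3 stands highest of the three: a number 11 percentage points higher from compound 2 to compound 3 (beyond the scatter), and a number 39 percentage points higher from compound 1 to compound 3 (beyond the scatter). The smaller of these two steps is a number 28 percentage points higher from compound 1 to compound 2 (beyond the scatter).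

Compound 4 differs from compound 3 in a single atom: methyl in place of fluoro on a saturated ring carbon. Among the measured compounds shown here, none of the measured steps bears directly on this swap; each of them exchanges the whole group on the carbonyl carbon, and none replaces fluoro by methyl on a saturated ring carbon. What the measured steps do show is that each small ring on the carbonyl carbon gives a larger maximal response than isopropyl, and compound 4 keeps such a ring. Compound 4 is therefore expected to stay close to its neighbor, the expected step being a number 10 percentage points lower from compound 3 to compound 4 (within the scatter). Compound 4 is estimated at 100%, within a range from 80% to 120%.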

Compound 4, largest response reached (Emax), in percent of the reference or control that the assay uses: 110%
Estimate against measurement, compound 4: 10 percentage points below; measured number inside the range.
By their numbers in this assay, from the lowest: compound 1; then compound 2; then compounds 3 and 4 (each within the scatter of the next).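

In this assay, a methyl in place of fluoro on this saturated ring carbon leaves the maximal response where it was (no change at the digits printed from compound 3 to compound 4 (within the scatter)), so on this read-out the two groups cannot be told apart at this position. The 2-methylcyclopropyl group on the carbonyl carbon also stands clear of both earlier groups, cyclobutyl (a number 11 percentage points higher from compound 2 to compound 4 (beyond the scatter)) and isopropyl (a number 39 percentage points higher from compound 1 to compound 4 (beyond the scatter)), just as 2-fluorocyclopropyl does. Nothing available explains why the two ring groups give such matching results.

Still open, from the compounds shown here alone, is whether a hydroxymethyl, an amine or a trifluoromethyl on the same ring carbon would hold this response. Also open, going by these compounds, is how a plain cyclopropyl group on the carbonyl carbon, with nothing on its ring, would compare.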